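The source may report more compounds than this note shows. Statements on the series, on what has been measured and on what is new or still open speak of the compounds shown alone.

Of the compounds shown here, three that share one core have been tested in a functional assay on MDA-MB-231 cells (Homo sapiens) for inhibition, read by MTT assay, with a stated time of 24 h; a higher number here means a weaker inhibitor, a lower number a stronger inhibitor. Compound 1 `[O-]/[N+](=C\c1cn(-c2ccc(F)cc2)nn1)c1ccccc1` carries a phenyl on the double-bonded nitrogen and a fluorophenyl on the ring nitrogen; in this assay compound 1 gives 9800 nM. Compound 2 `CCCCCCCCCCn1cc(/C=[N+](\[O-])c2ccccc2)nn1` keeps the phenyl on the double-bonded nitrogen but carries a decyl chain on the ring nitrogen. For compound 2 this assay reports only a limit, > 100000 nM. Compound 3 `[O-]/[N+](=C\c1cn(-c2ccc(C(F)(F)F)cc2)nn1)Cc1ccccc1` carries a benzyl on the double-bonded nitrogen and a trifluoromethylphenyl on the ring nitrogen. For compound 3 the result is likewise a limit, > 100000 nM. Compound 2 therefore stands at the limit of > 100000 nM in this assay, at which 2 of the 3 values shown sit, and no number can be attached to it from what has been measured.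

Compound 4 `CCCCCCCCCCn1cc(/C=[N+](\[O-])Cc2ccccc2)nn1` is the next one to be measured. It differs from compound 2 by benzyl in place of phenyl on a double-bonded nitrogen. Within the data shown here, no measured pair shows this change on its own, and the start point, compound 2, is itself only a limit. Compound 2 with its decyl chain and compound 3 with its benzyl both reached only a limit, so compound 4, which combines the two, is expected to stay at that limit as well. The expected step is a step that the limit leaves unreadable from compound 2 to compound 4, nothing beyond the scatter. Compound 4 is thus estimated at 150000 nM, with a range from 60000 nM to 500000 nM.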

Compound 4, half-maximal inhibitory concentration: > 100000 nM
Compound 4 gave a limit, no number (the forecaster's own chance of this, stated with the estimate: 80%); the middle value lies beyond the limit too.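

Compound 2 and compound 4 both give only a limit, not a number, so the step between them, benzyl in place of phenyl, cannot be read. Compound 4 joins compound 2 at the same limit: the limit of > 100000 nM in this assay, at which 3 of the 4 values shown sit. The compounds shown leave open whether this swap changes potency at all when the starting compound has a measured number.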